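The source may hold more compounds than are shown below. What is called first, only, known or untested is meant among the compounds shown, and "the series" means these compounds.

Compound 2, `Fc1ccc(C2CC(c3ccc(Cl)s3)=NN2c2nc(-c3ccc(C(F)(F)F)cc3)cs2)cc1`, stands at the edge of what an ADME assay on NIH3T3 cells (Mus musculus) for cytotoxicity, read by XTT assay, with a stated time of 24 h (a lower number here means a stronger inhibitor, a higher number a weaker inhibitor), can report: in this assay compound 2 gives > 500 ug/mL, which is a limit and not a number. Compound 1, `Cc1ccc(C2=NN(c3nc(-c4ccc(C#N)cc4)cs3)C(c3ccc(F)cc3)C2)s1`, gives 250 ug/mL in this assay. Compound 3, `Cc1ccc(C2=NN(c3nc(-c4ccc(C(F)(F)F)cc4)cs3)C(c3ccc(F)cc3)C2)s1`, also returns only a limit in this assay, at > 500 ug/mL. Two of the three values therefore sit at the limit of > 500 ug/mL in this assay, at which 2 of the 3 values shown sit. Replacing cyano with trifluoromethyl gave an at least 2.0-fold higher number from compound 1 to compound 3 (0.30 log units; that floor lies within the scatter), while the methyl-for-chloro exchange gave a step that the two limits leave unreadable from compound 2 to compound 3.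

Compound 4, `Fc1ccc(-c2csc(N3N=C(c4ccc(Cl)s4)CC3c3ccc(F)cc3)n2)cc1`, differs from compound 2 by fluoro in place of trifluoromethyl on an aromatic carbon. Going by the values given here, no measured step exchanges fluoro for trifluoromethyl, so the only bearing comes from the trifluoromethyl compounds 2 and 3, both at the limit, and from the cyano-to-trifluoromethyl step an at least 2.0-fold higher number from compound 1 to compound 3 (0.30 log units; that floor lies within the scatter), whose floor lies within the scatter. Compound 4 is therefore expected to stay near that limit, with an estimated at least 1.2-fold lower number from compound 2 to compound 4 (0.09 log units; that floor lies within the scatter) that does not exceed the scatter. The estimate for compound 4 in this assay is 400 ug/mL, ranging from 150 ug/mL to 500 ug/mL.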

Compound 4, half-maximal inhibitory concentration: > 500 ug/mL
Compound 4 was reported as a limit (the forecaster's own chance of this, stated with the estimate: 55%); at least 1.2-fold (0.09 log units) between middle value and limit.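

The step from compound 2 to compound 4 cannot be read, because both results are limits and not numbers: the limit of > 500 ug/mL in this assay, at which 3 of the 4 values shown sit. The compounds shown leave open how far 4-fluorophenyl in place of 4-(trifluoromethyl)phenyl moves the number in this assay, and how compound 2, compound 3 and compound 4 rank among themselves.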